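The source may report more compounds than this note shows. Statements on the series, on what has been measured and on what is new or still open speak of the compounds shown alone.

Three compounds share one core, carrying a ring group on an aromatic carbon. Compound 1 `c1ccc(-c2cnoc2)c(NCC2=NCCN2)c1` reaches only a limit in a functional assay for activation of Alpha-1B adrenergic receptor (Homo sapiens), read by calcium flux; a higher number here means that more compound is needed for the effect, a lower number that less compound is needed: in this assay compound 1 gives < 100000 nM, a limit and not a number (the limit of < 100000 nM in this assay, at which 1 of the 3 values shown sits). Compound 2 `Cc1nc(-c2ccccc2NCC2=NCCN2)no1` gives 676 nM in this assay. For the measured compounds named here, compound 3 `c1ccc(-c2ccccc2NCC2=NCCN2)nc1` gives 30.2 nM in this assay, the lowest of the two numbers, and the only readable step is a 22-fold lower number from compound 2 to compound 3 (1.35 log units; beyond the scatter). Compound 4 `c1ccc(-c2cnccn2)c(NCC2=NCCN2)c1` differs from compound 3 by pyrazin-2-yl in place of pyridin-2-yl on an aromatic carbon. That measured step swapped a five-membered ring for a six-membered one, a larger change than this, so a smaller effect is expected here, estimated as a 2.3-fold higher number from compound 3 to compound 4 (0.37 log units; beyond the scatter). Compound 4 is therefore expected to give about 70 nM in this assay, within 20 nM to 300 nM.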

Compound 4, half-maximal effective concentration: 339 nM
The estimate for compound 4 lay 4.8-fold (0.69 log units) below the measured number; the measured number lies above the stated range.
By their numbers in this assay, from the lowest: compound 3; then compounds 4 and 2 (each within the scatter of the next).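

Pyrazin-2-yl keeps the six-membered aromatic ring of pyridin-2-yl and adds a second ring nitrogen, yet the swap gives an 11-fold higher number from compound 3 to compound 4 (1.05 log units; beyond the scatter), so a six-membered ring alone does not secure the low number of compound 3. Its five-membered counterpart gives a 2.0-fold lower number from compound 2 to compound 4 (0.30 log units; within the scatter), so ring size does not separate these two compounds. Any step from compound 1 cannot be read, because compound 1 stands at a limit: the limit of < 100000 nM in this assay, at which 1 of the 4 values shown sits.

Open, going by these compounds, is how a plain phenyl ring, with no ring nitrogen, would compare at this position. Also open, on these data alone, is what an amine on the pyridin-2-yl ring would do.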